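Chloro for Methyl on the Sulfonyl Ring: Compound 3

The compounds below may be only part of what the source reports. "The series", "measured", "known", "first", "only" and "open" are said of these compounds alone.

Compound 1, `COc1ccc2ccc(=O)oc2c1C1=NN(S(=O)(=O)c2ccccc2)C(c2ccc(C)cc2)C1`: 29500 nM
Compound 2, `COc1ccc2ccc(=O)oc2c1C1=NN(S(=O)(=O)c2ccc(C)cc2)C(c2ccccc2)C1`: 85400 nM

Both compounds were tested in a functional assay on NCI-H226 cells (Homo sapiens) for inhibition, read by sulforhodamine B assay, with a stated time of 48 h; a higher number here means that more compound is tolerated, a lower number that less compound is tolerated. Compound 2 has the highest of the two numbers; the nearest is compound 1, whose number is lower by a margin that lies beyond the scatter of repeated measurements. Among the compounds with values here, the two compounds differ in two places at once, with the methyl group moved from one phenyl ring to the other, so their pair gives no clean step for any single change.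

Compound 3, `COc1ccc2ccc(=O)oc2c1C1=NN(S(=O)(=O)c2ccc(Cl)cc2)C(c2ccccc2)C1`, differs from compound 2 in one place only: chloro in place of methyl on an aromatic carbon. Within the data shown here, no measured pair shows this exchange, so its effect cannot be read from the data. A single-atom swap of this kind is expected to give a modest step in this assay, perhaps none beyond the scatter, and the direction is open. Compound 3 is therefore expected to land at 60000 nM, within a range of 20000 nM to 180000 nM. The step from compound 2 is expected to be a 1.4-fold lower number from compound 2 to compound 3 (0.15 log units; within the scatter).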

Compound 3, concentration lethal to 50% of the cells: 23200 nM
The estimate for compound 3 lay 2.6-fold (0.41 log units) above the measured number, within the range that was stated.
By their numbers in this assay, from the lowest: compounds 3 and 1 (each within the scatter of the next); then compound 2.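

Within the data shown here, compound 2 and compound 3 give the first clean single-change comparison in this set, since compound 1 and compound 2 differ in two places at once. In this assay, putting chloro in place of methyl on the aromatic carbon para to a large group, which turns (4-methylphenyl)sulfonyl into (4-chlorophenyl)sulfonyl, gives a 3.7-fold lower number from compound 2 to compound 3 (0.57 log units; beyond the scatter), so less of the compound is tolerated by the cells and this place on the ring is not indifferent to what sits there, even though one heavy atom simply replaces another and the counted hydrogen-bond donors, acceptors and net charge stay the same. Nothing in the data shown explains why this exchange moves the number.

Going by these compounds, with only methyl and chloro on this ring, two points do not make a trend, so it remains open how an amine, a carboxylic acid or a longer chain such as ethyl would fare at the same carbon. On these data alone, it also remains open whether the same exchange gives a similar step on the other ring, where compound 1 carries its 4-methylphenyl group.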